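The source may report more compounds than this note shows. Statements on the series, on what has been measured and on what is new or still open speak of the compounds shown alone.

Three compounds share one core and differ only in the group on the benzyl ring attached to sulfur. Compound 1 `Cc1cc(S(=O)(=O)/N=C(\N)N/N=C/C#Cc2ccccc2)c(SCc2ccccc2C)cc1Cl` gives 13000 nM in a functional assay on MCF7 cells (Homo sapiens) for antiproliferative activity, read by MTT assay, with a stated time of 72 h; on this read-out higher numbers stand for weaker inhibition and lower numbers for stronger inhibition. Compound 2 `Cc1cc(S(=O)(=O)/N=C(\N)N/N=C/C#Cc2ccccc2)c(SCc2ccccc2C(F)(F)F)cc1Cl` gives 14000 nM in this assay, and compound 3 `Cc1cc(S(=O)(=O)/N=C(\N)N/N=C/C#Cc2ccccc2)c(SCc2ccccc2Cl)cc1Cl` gives 15000 nM. The three values lie close together: the step from compound 1 to compound 2 was a 1.1-fold higher number from compound 1 to compound 2 (0.03 log units; within the scatter), that from compound 1 to compound 3 was a 1.2-fold higher number from compound 1 to compound 3 (0.06 log units; within the scatter), and that from compound 2 to compound 3 was a 1.1-fold higher number from compound 2 to compound 3 (0.03 log units; within the scatter). Compound 3 gives the highest of the three numbers, but each of its gaps to the others is within the scatter, so no order can be read from them.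

Compound 4 `Cc1cc(S(=O)(=O)/N=C(\N)N/N=C/C#Cc2ccccc2)c(SCc2ccc(Cl)cc2)cc1Cl` keeps the chlorine but moves it: the change is 4-chlorophenyl in place of 2-chlorophenyl on a saturated chain carbon bound to a sulfur. Among the measured compounds shown here, none of the measured steps moves a group around this ring; they only swap groups at one place, and all three stayed within the scatter. That pattern suggests the step from compound 3 to compound 4 is expected to be no change at the digits printed from compound 3 to compound 4 (within the scatter), in this assay. Compound 4 is therefore estimated at 15000 nM, with a range from 7000 nM to 32000 nM.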

Compound 4, half-maximal inhibitory concentration: 18000 nM
Compound 4: the middle estimate sits 1.2-fold (0.08 log units) below what was measured; the range from low to high includes it.
By their numbers in this assay, from the lowest: compounds 1, 2, 3 and 4 (each within the scatter of the next).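

Moving the chlorine, from 2-chlorobenzyl to 4-chlorobenzyl on the sulfur, is the first step in this set that alters where a group sits on this ring rather than which group sits there, and in this assay it reads a 1.2-fold higher number from compound 3 to compound 4 (0.08 log units; within the scatter). The two steps from the other groups read a 1.3-fold higher number from compound 2 to compound 4 (0.11 log units; within the scatter) and a 1.4-fold higher number from compound 1 to compound 4 (0.14 log units; within the scatter), so neither the choice of group nor the place of the chlorine separates these four compounds on this read-out. Nothing measured here offers a reason for this flat picture.

Still open, on these data alone, is whether an amine or a carboxylic acid on this ring would give a step beyond the scatter. A longer chain between the sulfur and the ring is equally untested by the compounds shown.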